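Compound 4 in this assay: cyano to methyl

The source may report more compounds than this note shows. Statements on the series, on what has been measured and on what is new or still open speak of the compounds shown alone.

Three compounds share one core and differ only in the aryl group attached to it. Compound 1 `Cc1nn(-c2nc(-c3ccc(Cl)c(Cl)c3)c(SC(C)C)s2)c(C(=O)O)c1-c1cccc(Cl)c1C` gives 5100 nM in a functional assay on BJAB cells (Homo sapiens) for antiproliferative activity, with a stated time of 4 days; a higher number here means that more compound is needed for the effect, a lower number that less compound is needed. Compound 2 `Cc1cc(-c2c(C)nn(-c3nc(-c4ccc(Cl)c(Cl)c4)c(SC(C)C)s3)c2C(=O)O)cc(C)n1` gives 580 nM, and compound 3 `Cc1cc(C#N)cc(-c2c(C)nn(-c3nc(-c4ccc(Cl)c(Cl)c4)c(SC(C)C)s3)c2C(=O)O)c1` gives 4800 nM. Among these three numbers compound 3 stands second highest: the step of a 1.1-fold lower number from compound 1 to compound 3 (0.03 log units; within the scatter) is within the scatter, while the step of an 8.3-fold higher number from compound 2 to compound 3 (0.92 log units; beyond the scatter) is beyond it.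

Compound 4 `Cc1cc(C)cc(-c2c(C)nn(-c3nc(-c4ccc(Cl)c(Cl)c4)c(SC(C)C)s3)c2C(=O)O)c1` is not yet measured. It differs from compound 3 by methyl in place of cyano on an aromatic carbon. Within the data shown here, no measured pair here changes a cyano into a methyl, so the expectation rests on the nearest case: the step of a 1.1-fold lower number from compound 1 to compound 3 (0.03 log units; within the scatter) shows that swapping one substituted phenyl for another left the number within the scatter, whereas the step of an 8.8-fold lower number from compound 1 to compound 2 (0.94 log units; beyond the scatter) involved a ring of a different kind. On this basis the step of a 1.2-fold lower number from compound 3 to compound 4 (0.08 log units; within the scatter) is expected to stay within the scatter. Compound 4 is therefore estimated at 4000 nM, with a range from 1500 nM to 12000 nM.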

Compound 4, half-maximal effective concentration: 2700 nM
Estimate against measurement, compound 4: 1.5-fold (0.17 log units) above; the range from low to high includes it.
By their numbers in this assay, from the lowest: compound 2; then compounds 4, 3 and 1 (each within the scatter of the next).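

Replacing the nitrile of the 3-cyano-5-methylphenyl group with a methyl is tolerated at this place in this assay, with a 1.8-fold lower number from compound 3 to compound 4 (0.25 log units; within the scatter). The 3,5-dimethylphenyl group also cannot be told apart from the 3-chloro-2-methylphenyl group (a 1.9-fold lower number from compound 1 to compound 4 (0.28 log units; within the scatter)), so the three phenyl groups shown now stand together, while the 2,6-dimethylpyridin-4-yl group stays apart even from the phenyl ring that also carries two methyl groups (a 4.7-fold higher number from compound 2 to compound 4 (0.67 log units; beyond the scatter)). Nothing measured here explains why the pyridine ring stands apart from the phenyl rings.

Still open, from the compounds shown here alone, is whether an amine or a methoxy group on the phenyl ring would move the number beyond the scatter. Going by these compounds, it is also open whether a pyridine ring without its two methyl groups would stay close to compound 2.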